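The source may hold more compounds than are shown below. What is called first, only, known or untested is meant among the compounds shown, and "the series" means these compounds.

Measured so far:
compound 1 `CNC(=O)[C@@]12C[C@@H]1[C@@H](n1cnc3c(NC)nc(C#Cc4cccc(F)c4)nc31)[C@H](O)[C@@H]2O` — in an assay on CHO cells for displacement of a labelled ligand from adenosine receptor A1 (Homo sapiens), read by scintillation counting, with a stated time of 60 min, tested at 10 uM (a lower number here means less inhibition, a higher number more inhibition at the concentration tested (going by the name of the read-out)), compound 1 gives 14%
compound 2 `CNC(=O)[C@@]12C[C@@H]1[C@@H](n1cnc3c(NC)nc(C#Cc4ccc(OC)cc4)nc31)[C@H](O)[C@@H]2O` — in this assay compound 2 gives 10%

Among the measured compounds shown here, compound 2 holds the lowest of the two numbers in this assay, with compound 1 nearest; the one measured step is a number 4 percentage points lower from compound 1 to compound 2 (within the scatter), so the two values are not ordered. Compound 3 `CNC(=O)[C@@]12C[C@@H]1[C@@H](n1cnc3c(NC)nc(C#Cc4cnn(C)c4)nc31)[C@H](O)[C@@H]2O` differs from compound 2 by 1-methyl-1H-pyrazol-4-yl in place of 4-methoxyphenyl on a triple-bonded carbon. For the measured compounds named here, the only step that bears on this is the same kind of exchange at the same place, a number 4 percentage points lower from compound 1 to compound 2 (within the scatter). For compound 3 the expected step is therefore a number 2 percentage points higher from compound 2 to compound 3 (within the scatter), none beyond the scatter. Compound 3 is estimated at 12% in this assay, expected range 2% to 24%.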

Compound 3, a percentage reported as inhibition, at one concentration (the size of the read-out at that concentration, not a potency): 35%
Beside the measured number, compound 3's estimate is 23 percentage points below it, and the stated range ends below it.
By their numbers in this assay, from the lowest: compounds 2 and 1 (each within the scatter of the next); then compound 3.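

Going to 1-methyl-1H-pyrazol-4-yl on a triple-bonded carbon gives a number 25 percentage points higher from compound 2 to compound 3 (beyond the scatter) and a number 21 percentage points higher from compound 1 to compound 3 (beyond the scatter) in this assay and so shows that this position can register a change in the group it carries. Among the compounds shown here, the exchange between the two substituted phenyl groups had left the values unordered, so the first step beyond the scatter comes with the five-membered aromatic ring. Nothing available accounts for this rise.

From the compounds shown here alone, whether it depends on the ring itself or on its methyl group remains open. So does the outcome at this place with a pyridine ring, an amine or a carboxylic acid.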